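The compounds below may be only part of what the source reports. "The series", "measured", "known", "first", "only" and "open" are said of these compounds alone.

Compound 1 `CC(=O)Oc1cccc(N2C(=O)/C(=C/N3N=C(c4ccccc4)CC3c3ccc(N(C)C)cc3)SC2=S)c1` and compound 2 `CN(C)c1ccc(C2CC(c3ccccc3)=NN2/C=C2\SC(=S)NC2=O)cc1` share one core, while compound 3 `CC(=O)Oc1cccc(N2C(=O)/C(=C/N3N=C(c4ccc5ccccc5c4)CC3c3ccc(Cl)cc3)SC2=S)c1` and compound 4 `O=C1NC(=S)S/C1=C\N1N=C(c2ccc3ccccc3c2)CC1c1ccc(Cl)cc1` share another; the difference between the two cores is not broken down here. In a functional assay on SK-OV-3 cells (Homo sapiens) for antiproliferative activity, read by MTT assay, with a stated time of 72 h (on this read-out higher numbers stand for weaker inhibition and lower numbers for stronger inhibition), compound 1 gives only a limit, > 10000 nM. Compound 2 likewise gives only a limit, > 10000 nM, in this assay. The change hydrogen in place of 3-acetoxyphenyl on an amide-type nitrogen in a ring therefore produces a step that the two limits leave unreadable from compound 1 to compound 2, since (the limit of > 10000 nM in this assay, at which 2 of the 3 values shown sit). Among the compounds with values here, compound 3 reaches 2390 nM in this assay, the one number known. Compound 4 carries the same kind of change, (hydrogen in place of 3-acetoxyphenyl on an amide-type nitrogen in a ring). With the earlier step unreadable, the size of the step from compound 3 is expected to be a 2.1-fold higher number from compound 3 to compound 4 (0.32 log units; beyond the scatter), a guess that rests on nothing firmer than the two limits seen for compound 1 and compound 2. Compound 4 is thus estimated at 5000 nM, between 1500 nM and 15000 nM.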

Compound 4, half-maximal inhibitory concentration: 163 nM
Compound 4: middle estimate off by 31-fold (1.49 log units), on the high side; measured number outside the range, below it.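

In this assay, hydrogen in place of 3-acetoxyphenyl on the amide-type nitrogen in the ring gives a 15-fold lower number from compound 3 to compound 4 (1.17 log units; beyond the scatter), so in this core the change brings much stronger inhibition. From the compounds shown here alone, whether that step carries over between cores stays unknown, since the same change in the core of compound 1 cannot be read: the limit of > 10000 nM in this assay, at which 2 of the 4 values shown sit. One readable step in one core sets no rule for the series.

Going by these compounds, it remains open whether a small group such as methyl, or a longer chain ending in a carboxylic acid, on that nitrogen would keep the inhibition seen with hydrogen. Also open, on these data alone, is which part of the core difference separates compound 2 from compound 4, as they differ in more than one place.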